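This account rests on a few compounds, and the source may have more. Where it says the series, first, only, none or still open, it means among the compounds named here.

Measured so far in an ADME assay on microsomes from liver (Homo sapiens) for metabolic stability; on this read-out lower numbers stand for a shorter-lived compound and higher numbers for a longer-lived compound:
compound 1 `CCn1ncc2c1-c1ccnc(c1)[C@@H](N1CCC(c3cc(Cl)ccc3-n3ccnn3)=CC1=O)CCC[C@@H](C)C(=O)N2` gives 0.167 h
compound 2 `C[C@@H]1CCC[C@H](n2cnc(-c3cc(Cl)ccc3-n3cc(Cl)nn3)cc2=O)c2cc(ccn2)-c2c(cnn2C)NC1=O` gives 1.93 h

Among the measured compounds shown here, compound 1 stands lowest of the two numbers; compound 2 shows a number well beyond the scatter above it, though no single-point step links the pair. Compound 3 `C[C@@H]1CCC[C@H](N2CCC(c3cc(Cl)ccc3-n3ccnn3)=CC2=O)c2cc(ccn2)-c2c(cnn2C2CC2)NC1=O` differs from compound 1 by a (cyclopropyl in place of ethyl on an aromatic nitrogen). For the measured compounds named here, no step of this kind has been measured here, so the expected change in this assay is judged small: a modest rise, at the edge of the scatter. The expected step is a 1.8-fold higher number from compound 1 to compound 3 (0.25 log units; within the scatter). For compound 3 the estimate is 0.3 h, within 0.12 h to 0.75 h.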

Compound 3, half-life: 0.0833 h
Beside the measured number, compound 3's estimate is 3.6-fold (0.56 log units) above it; the whole stated range lies above it.
By their numbers in this assay, from the lowest: compounds 3 and 1 (each within the scatter of the next); then compound 2.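

In this assay, cyclopropyl in place of ethyl on the aromatic nitrogen gives a 2.0-fold lower number from compound 1 to compound 3 (0.30 log units; within the scatter), the first single-place step read at this position. Adding a three-membered ring of carbon at this nitrogen therefore does not move the half-life beyond the usual scatter. No measurement shown here offers an explanation for this step. On these data alone, whether a longer chain, a methoxyethyl group or a chain ending in an amine on this nitrogen would move the half-life beyond the scatter remains open.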